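The source may hold more compounds than are shown below. What is called first, only, known or untested is meant among the compounds shown, and "the series" means these compounds.

In a functional assay on HUVEC cells (Homo sapiens) for antiproliferative activity, read by MTT assay, with a stated time of 48 h (on this read-out higher numbers stand for weaker inhibition and lower numbers for stronger inhibition), compound 2 `Fc1cccc(/C=C/c2nnc(-c3ccc4c(c3)OCCO4)o2)c1` gives 3530 nM, the higher of the two numbers recorded, while compound 1 `Fc1ccccc1/C=C/c1nnc(-c2ccc3c(c2)OCCO3)o1` gives 1160 nM; the step of a 3.0-fold higher number from compound 1 to compound 2 (0.48 log units; beyond the scatter) is modest. Compound 3 `COc1cccc(/C=C/c2nnc(-c3ccc4c(c3)OCCO4)o2)c1` differs from compound 2 by methoxy in place of fluoro on an aromatic carbon. Among the compounds with values here, no measured step exchanges fluoro for another group; the only recorded step compares two fluorophenyl isomers, so it bears on this change only loosely. A number close to that of compound 2 is therefore expected for compound 3, a 1.2-fold lower number from compound 2 to compound 3 (0.07 log units; within the scatter). Compound 3 is estimated at 3000 nM, within 1000 nM to 9000 nM.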

Compound 3, half-maximal inhibitory concentration: > 50000 nM
Compound 3: no number, only a limit (the forecaster's own chance of this, stated with the estimate: 5%); middle value at least 16-fold (1.22 log units) away from the limit.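

The earlier compounds shown here only moved fluoro around the ring, with a modest effect; replacing fluoro with methoxy on the same aromatic carbon gives an at least 14-fold higher number from compound 2 to compound 3 (1.15 log units; beyond the scatter), and starting from the 2-fluorophenyl group the step is an at least 43-fold higher number from compound 1 to compound 3 (1.63 log units; beyond the scatter). Across these three compounds, which group stands on this ring counts for more than where fluoro sits. Compound 3 carries a limit and not a number: the limit of > 50000 nM in this assay, at which 1 of the 3 values shown sits.

The compounds shown leave open how large these steps really are. They also leave open whether a hydroxyl, a chlorine or an amine on this carbon would stay close to compound 2 or reach the same limit.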